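This account rests on a few compounds, and the source may have more. Where it says the series, first, only, none or still open, it means among the compounds named here.

Measured so far in a functional assay on T47D cells (Homo sapiens) for antiproliferative activity, read by MTT assay, with a stated time of 72 h; a lower number here means a stronger inhibitor, a higher number a weaker inhibitor:
Compound 1 `Cc1nc(C(=O)Nc2ccc(Cl)c(-c3nnc4c(Cl)cccn34)c2)cs1` gives > 100000 nM, a limit of the assay.
Compound 2 `O=C(Nc1ccc(Cl)c(-c2nnc3c(Cl)cccn23)c1)c1ccccc1Cl` gives 83800 nM.
Compound 3 `O=C(Nc1ccc(Cl)c(-c2nnc3c(Cl)cccn23)c1)c1ccc(C(F)(F)F)cc1Cl` gives > 100000 nM, a limit of the assay.

Among the compounds with values here, compound 2 therefore holds the only number measured in this assay; the other two values sit at the limit of > 100000 nM in this assay, at which 2 of the 3 values shown sit. Compound 4 `O=C(Nc1ccc(Cl)c(-c2nnc3c(Cl)cccn23)c1)c1ccc(F)cc1Cl` differs from compound 2 by fluoro in place of hydrogen on an aromatic carbon. Within the data shown here, the one measured step at that place is an at least 1.1-fold higher number from compound 2 to compound 3 (0.07 log units; that floor lies within the scatter), a floor within the scatter, and the step of an at least 1.1-fold lower number from compound 1 to compound 2 (0.07 log units; that floor lies within the scatter) also stays within it. Nothing here points beyond the scatter, so the account expects at most a small shift toward a higher number in this assay. Compound 4 is estimated at 100000 nM, between 40000 nM and 250000 nM. That estimate means a 1.2-fold higher number from compound 2 to compound 4 (0.08 log units; within the scatter), expected to lie within the scatter, with a fair chance that only a limit is reported.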

Compound 4, half-maximal inhibitory concentration: > 100000 nM
Compound 4: no number, only a limit; the forecaster's own chance of this, stated with the estimate: 55%; the middle value lies on the limit itself.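

In this assay, going by these compounds, fluoro at the place para to a large group gives an at least 1.1-fold higher number from compound 2 to compound 4 (0.07 log units; that floor lies within the scatter); this is only a floor, and the true size is unknown. Compound 4 now joins compound 3 in showing that neither a small nor a larger group there yields a number, and its value is a limit of the assay: the limit of > 100000 nM in this assay, at which 3 of the 4 values shown sit. The steps to compound 4 from compound 3 and from compound 1 cannot be read.

On these data alone, whether an amine or a methoxy group at this place would give a number stays open. So does how far past the limit compound 4 lies.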